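Swapping a Difluorophenyl for a Cyanophenyl Group

The source may hold more compounds than are shown below. What is called first, only, known or untested is meant among the compounds shown, and "the series" means these compounds.

Of the compounds shown here, three sharing one core have been measured in an assay on isolated protein for inhibition of protein deacetylase HDAC6 (Homo sapiens), read by fluorescence, with a stated time of 1 h, tested at 100 nM; on this read-out lower numbers stand for less inhibition and higher numbers for more inhibition at the one concentration tested (going by the name of the read-out). Compound 1 `O=C(/C=C/c1ccc(OCc2nc(C3CCN(Cc4ccccc4)CC3)no2)cc1)NO` gives 71%, compound 2 `O=C(/C=C/c1ccc(OCc2nc(C3CCN(Cc4ccccc4F)CC3)no2)cc1)NO` gives 68%, and compound 3 `O=C(/C=C/c1ccc(OCc2nc(C3CCN(Cc4ccc(F)cc4F)CC3)no2)cc1)NO` gives 74%. Compound 3 carries the highest of the three numbers, but its gap to compound 1, a number 3 percentage points higher from compound 1 to compound 3 (within the scatter), and its gap to compound 2, a number 6 percentage points higher from compound 2 to compound 3 (within the scatter), both lie within the usual scatter, so the three compounds cannot be told apart on these numbers.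

Compound 4 `N#Cc1ccc(CN2CCC(c3noc(COc4ccc(/C=C/C(=O)NO)cc4)n3)CC2)cc1` has not yet been measured. It differs from compound 3 by a single change: 4-cyanophenyl in place of 2,4-difluorophenyl on a saturated chain carbon bound to an amine nitrogen in a ring. Every step seen so far alters the group on a saturated chain carbon bound to an amine nitrogen in a ring: a number 3 percentage points lower from compound 1 to compound 2 (within the scatter) and a number 3 percentage points higher from compound 1 to compound 3 (within the scatter), neither of them beyond the scatter. Those steps add only fluorine atoms, and none of them introduces a nitrile, so their bearing on compound 4 is indirect. Even so, with the group at this place varied three ways and the read-out unmoved, the expected step of a number 4 percentage points lower from compound 3 to compound 4 (within the scatter) is one with no change beyond the scatter in this assay. Compound 4 is therefore estimated at 70%, with a range from 55% to 82%.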

Compound 4, a percentage reported as inhibition, at one concentration (the size of the read-out at that concentration, not a potency): 65%
Compound 4: the middle estimate sits 5 percentage points above what was measured, within the range that was stated.
By their numbers in this assay, from the lowest: compounds 4, 2, 1 and 3 (each within the scatter of the next).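

Compound 4 carries the only nitrile among the four compounds, and so the only hydrogen-bond acceptor in this aryl group, and in this assay adding it to the plain phenyl ring of compound 1 gives a number 6 percentage points lower from compound 1 to compound 4 (within the scatter). Set against the fluorinated rings, the nitrile gives a number 3 percentage points lower from compound 2 to compound 4 (within the scatter) and a number 9 percentage points lower from compound 3 to compound 4 (within the scatter), so even the largest of these steps cannot be told apart from repeat-to-repeat variation, and this position has now accepted a cyano group as well as fluoro groups without a clear shift in the read-out. No supporting measurement accompanies these compounds to explain this result.

Every group shown at this place is still a benzyl group, so it remains open whether a carboxylic acid or an amine on the ring, a longer chain linking the ring to the amine nitrogen, or a plain methyl in place of the benzyl would move the number beyond the scatter. These are also percentages at a single concentration, which leaves any potency differences among the four compounds unresolved.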